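A few compounds are considered here, and "the series" means these few. Any claim that something is new, unique, unknown or untested is made for them only; others in the source may bear on it.

Working notes on the series, starting from compound 3 (`COc1ccc(-c2nc(C(=O)N3CCCCC3)sc2-c2ccc(OC)cc2)cc1`). In a functional assay (aorta) with Rattus norvegicus as the target (on this read-out lower numbers stand for an effect already at smaller amounts and higher numbers for an effect only at larger amounts of compound), compound 3 gives 11 uM and compound 2 (`CNC(=O)NCc1nc(-c2ccc(OC)cc2)c(-c2ccc(OC)cc2)s1`) gives 15 uM. These two sit level, since a 1.4-fold lower number from compound 2 to compound 3 (0.13 log units; within the scatter) stays within the scatter. Among the measured compounds shown here, compound 1 (`COc1ccc(-c2nc(N=C(N)N)sc2-c2ccc(OC)cc2)cc1`) gives 2 uM, the lowest number so far, and both steps away from it lie beyond the scatter: a 7.5-fold higher number from compound 1 to compound 2 (0.88 log units; beyond the scatter) and a 5.5-fold higher number from compound 1 to compound 3 (0.74 log units; beyond the scatter).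

Next is compound 4 (`COc1ccc(-c2nc(C3=CCN(C)CC3)sc2-c2ccc(OC)cc2)cc1`), with this change from compound 3: a group of 7 heavy atoms (6 carbon, 1 nitrogen; one six-membered non-aromatic ring with 1 hetero atom) in place of a group of 8 heavy atoms (6 carbon, 1 nitrogen, 1 oxygen; one six-membered non-aromatic ring with 1 hetero atom), on an aromatic carbon. For the measured compounds named here, no measured step makes this exact exchange. The two modest steps both start from the group on compound 1, which neither compound 3 nor compound 4 carries, so they bear on it only loosely. The closer guide is the exchange between compound 2 and compound 3, which left the number level. No step beyond the scatter is therefore expected in this assay. The expected step is a 1.4-fold lower number from compound 3 to compound 4 (0.14 log units; within the scatter). For compound 4 the estimated value is 8 uM, with an expected range of 3 uM to 20 uM.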

Compound 4, concentration for half-maximal effect: 5.9 uM
For compound 4 the middle estimate is 1.4-fold (0.13 log units) above the measured one; the range from low to high includes it.
By their numbers in this assay, from the lowest: compound 1; then compounds 4, 3 and 2 (each within the scatter of the next, the first and the last beyond it).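

At this position, on an aromatic carbon of a five-membered aromatic ring with 1 nitrogen and 1 sulfur, this assay gives a 1.9-fold lower number from compound 3 to compound 4 (0.27 log units; within the scatter), so a ring group without the carbonyl oxygen of (piperidin-1-yl)carbonyl holds the number level with compound 3. The new group also separates itself from the open-chain group of compound 2, with a 2.5-fold lower number from compound 2 to compound 4 (0.41 log units; beyond the scatter), even though compound 3 and compound 2 sit level and compound 4 and compound 3 sit level. The group on compound 1 keeps the lowest number, with a 3.0-fold higher number from compound 1 to compound 4 (0.47 log units; beyond the scatter), so no ring group shown here matches it.

The compounds shown leave open what a saturated 1-methylpiperidin-4-yl group would give at this position, and so whether the ring double bond of compound 4 matters. A simple aminomethyl group or a carboxylic acid there would test how far the result depends on the group on compound 1.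

No measurement at hand speaks to the reason for these differences.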